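From cyclohexyl to 4-bromophenyl in a cell assay

The source may hold more compounds than are shown below. What is called first, only, known or untested is meant among the compounds shown, and "the series" means these compounds.

- Compound 1 `Cc1cc(Nc2cc(-c3cccs3)[nH]n2)n2nc(SCc3ccc(Br)cc3)nc2n1` gives 4890 nM in this series
- Compound 2 `Cc1cc(Nc2cc(-c3ccccc3)[nH]n2)n2nc(SCC3CCCCC3)nc2n1` gives > 50000 nM as a limit

Both results come from a functional assay on PC-9 cells (Homo sapiens) for inhibition, read by MTT assay, with a stated time of 72 h (a lower number here means a stronger inhibitor, a higher number a weaker inhibitor), and are read as a half-maximal inhibitory concentration. Compound 2 stands at > 50000 nM as a limit of this assay and not a number. Compound 3 `Cc1cc(Nc2cc(-c3ccccc3)[nH]n2)n2nc(SCc3ccc(Br)cc3)nc2n1` has not yet been measured. Going from compound 2 to compound 3 puts 4-bromophenyl in place of cyclohexyl on a saturated chain carbon bound to a sulfur. Going by the values given here, no measured pair shows this change alone, so its effect can only be expected. Compound 3 shares the (4-bromobenzyl)sulfanyl group with compound 1, which gives 4890 nM in this assay and so points to a lower number for compound 3. The expected step (an at least 8.3-fold lower number from compound 2 to compound 3 (0.92 log units; beyond the scatter)) is large, towards stronger inhibition, and beyond the scatter. Compound 3 is estimated at 6000 nM (expected range 1800 nM to 20000 nM).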

Compound 3, half-maximal inhibitory concentration: 4760 nM
Compound 3: the middle estimate sits 1.3-fold (0.10 log units) above what was measured; measured number inside the range.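

In this assay, the change from cyclohexyl to 4-bromophenyl on a saturated chain carbon bound to a sulfur can now be read on its own, and it gives an at least 10-fold lower number from compound 2 to compound 3 (1.02 log units; beyond the scatter). Compound 2 is a limit and not a number, so this step shows only the smallest size the change can have: the limit of > 50000 nM in this assay, at which 1 of the 3 values shown sits. With the (4-bromobenzyl)sulfanyl group held in place, the other change, phenyl in place of thiophen-2-yl on an aromatic carbon, gives a 1.0-fold lower number from compound 1 to compound 3 (0.01 log units; within the scatter), so this assay does not tell these two rings apart.

The step to compound 3 brings in an aromatic ring and a bromine together, and the compounds shown do not separate the two, as a plain benzyl group in this place could. On these data alone, whether a pyridine ring in place of phenyl would also leave the number unchanged stays open.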